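A few compounds are considered here, and "the series" means these few. Any claim that something is new, unique, unknown or untested is made for them only; others in the source may bear on it.

Three compounds share one core and differ only in the group on an amine nitrogen in a ring of a six-membered non-aromatic ring with 2 nitrogen. Compound 1 `COc1ccc(N2CCN(Cc3csc(N)c3C(=O)c3ccc(Cl)cc3)CC2)cc1` gives 0% in a functional assay on CHO cells with adenosine receptor A1 (Homo sapiens) as the target, read by cAMP accumulation and immunoassay, with a stated time of 6 min, tested at 0.1 uM; a higher number here means a weaker effect of the compound at the concentration tested, a lower number a stronger effect; compound 2 `Nc1scc(CN2CCN(c3ccccc3C(F)(F)F)CC2)c1C(=O)c1ccc(Cl)cc1` gives -7.5%; compound 3 `Nc1scc(CN2CCN(c3ccc(Cl)c(C(F)(F)F)c3)CC2)c1C(=O)c1ccc(Cl)cc1` gives -12%. Compound 3 has the lowest of the three numbers, yet only its gap to compound 1 lies beyond the scatter: a number 12 percentage points lower from compound 1 to compound 3 (beyond the scatter), whereas a number 4.5 percentage points lower from compound 2 to compound 3 (within the scatter). Compound 4 `Nc1scc(CN2CCN(c3ccc(OC(F)(F)F)cc3)CC2)c1C(=O)c1ccc(Cl)cc1` carries 4-(trifluoromethoxy)phenyl in place of 4-chloro-3-(trifluoromethyl)phenyl on an amine nitrogen in a ring. All measured steps swap the group at this same nitrogen, and none was more than modest; a number 7.5 percentage points lower from compound 1 to compound 2 (within the scatter) as well. A step within the scatter is therefore expected: a number 6 percentage points higher from compound 3 to compound 4 (within the scatter). Compound 4 is estimated at -6%, with a range from -20% to 8%.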

Compound 4, a percentage reported as activity, at one concentration (the size of the read-out at that concentration, not a potency): -13%
The estimate for compound 4 lay 7 percentage points above the measured number; the range from low to high includes it.
By their numbers in this assay, from the lowest: compounds 4, 3, 2 and 1 (each within the scatter of the next, the first and the last beyond it).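

In this assay, a single small change to the group on the ring nitrogen is enough for a modest shift: trifluoromethyl in place of methyl on an oxygen on an aromatic ring (a number 13 percentage points lower from compound 1 to compound 4 (beyond the scatter)). The other two steps stay within the scatter (a number 1 percentage points lower from compound 3 to compound 4 (within the scatter); a number 5.5 percentage points lower from compound 2 to compound 4 (within the scatter)), so the three phenyl groups bearing trifluoromethyl or trifluoromethoxy cannot be told apart here. No evidence is available to explain the shift. Going by these compounds, whether a plain phenyl, or a phenyl carrying a nitrile or an amine, would read like compound 1 or like compound 4 stays open.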